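The source may report more compounds than this note shows. Statements on the series, on what has been measured and on what is new or still open speak of the compounds shown alone.

Compound 1 `O=S(=O)(c1ccccc1)N1CCOc2c(N3CCNCC3)cccc21` gives 12.6 nM in an assay on HEK293 cells for displacement of a labelled ligand from 5-hydroxytryptamine receptor 6 (Homo sapiens); on this read-out lower numbers stand for stronger inhibition and higher numbers for weaker inhibition.
Compound 2 `O=S(=O)(c1cccc2ccccc12)N1CCOc2c(N3CCNCC3)cc(Cl)cc21` gives 0.794 nM in this assay.

Of these two numbers, compound 2 has the lower one; compound 1 sits at a higher number, and the gap between the two lies beyond the usual scatter. Compound 2 differs from compound 1 in two places at once, so no single change can be credited with that gap.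

The next compound, compound 3 `O=S(=O)(c1ccccc1F)N1CCOc2c(N3CCNCC3)cc(Cl)cc21`, keeps the chlorine and the rest of the core of compound 2 and changes only the group on the sulfonyl sulfur: 2-fluorophenyl in place of naphthalen-1-yl on a sulfonyl sulfur. Within the data shown here, no measured pair shows this exact change on its own. Since the two measured compounds differ in more than one place, the part played by the naphthalen-1-yl group cannot be separated from the rest. The expected step from compound 2 to compound 3 is therefore uncertain, but a move toward a higher number, beyond the scatter, seems more likely than not. For compound 3 the estimate in this assay is 4 nM, with a range from 1 nM to 16 nM, which corresponds to an expected step of a 5.0-fold higher number from compound 2 to compound 3 (0.70 log units; beyond the scatter).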

Compound 3, inhibition constant: 0.398 nM
Beside the measured number, compound 3's estimate is 10-fold (1.00 log units) above it, and the stated range ends above it.
By their numbers in this assay, from the lowest: compounds 3 and 2 (each within the scatter of the next); then compound 1.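

Placing 2-fluorophenyl instead of naphthalen-1-yl on the sulfonyl sulfur gives a 2.0-fold lower number from compound 2 to compound 3 (0.30 log units; within the scatter) in this assay. At this position, then, a group with one six-membered aromatic ring and 7 heavy atoms reads the same, within the scatter, as one with 2 such rings and 10 heavy atoms, so the larger naphthalen-1-yl group is not required for a sub-nanomolar number on this core. Nothing shown explains why these two different groups give such similar numbers.

As far as these compounds go, the steps from compound 1 to compound 2 and to compound 3 cannot be read, since each pair differs in two places, so the separate contributions of the chlorine on the core and of the fluorine on the phenyl ring remain unknown. From the compounds shown here alone, it also remains open whether a non-aromatic group such as methyl or cyclohexyl, or a nitrogen-containing ring such as pyridin-3-yl, on the sulfonyl sulfur would keep the number in this range.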